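Demethylation of the aryl methyl ether in a pyrazole series

The source may report more compounds than this note shows. Statements on the series, on what has been measured and on what is new or still open speak of the compounds shown alone.

Compound 2 `COc1cc(C)cc(-c2nn(CC#N)cc2-c2ccnc(-c3ccc(N(C)C)cc3)c2)c1` was tested in a functional assay on NCI-H322M cells (Homo sapiens) for cytotoxicity, read by sulforhodamine B assay, with a stated time of 48 h, tested at 0.001 uM (a lower number here means a stronger effect, a higher number a weaker effect of the compound at the concentration tested), where compound 2 gives 99%. Its number sits together with those of its two neighbours, all within the usual scatter: compound 1 `COc1cc(C)cc(-c2c(-c3ccnc(-c4ccc(N(C)C)cc4)c3)cnn2CC#N)c1` gives 97% and compound 3 `COc1cc(C)cc(-c2nn(CC#N)cc2-c2ccc(-c3cccc(C(C)=O)c3)nc2)c1` gives 94%. Compound 4 `Cc1cc(O)cc(-c2nn(CC#N)cc2-c2ccnc(-c3ccc(N(C)C)cc3)c2)c1` has not yet been measured. It differs from compound 2 in one place (hydrogen in place of methyl on an oxygen on an aromatic ring). No comparable change between measured compounds is available, and all three measured values lie close to one another. The step from compound 2 to compound 4 is therefore expected to be a number 2 percentage points lower from compound 2 to compound 4 (within the scatter), none beyond the scatter. Compound 4 is estimated to give 97%, with a range from 88% to 104%.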

Compound 4, a percentage reported as activity, at one concentration (the size of the read-out at that concentration, not a potency): 94%
The estimate for compound 4 lay 3 percentage points above the measured number; measured number inside the range.
By their numbers in this assay, from the lowest: compounds 3, 4, 1 and 2 (each within the scatter of the next).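

In this assay, for the compounds shown here, the first one-place step, methoxy to hydroxy on the 3-methoxy-5-methylphenyl group, reads as a number 5 percentage points lower from compound 2 to compound 4 (within the scatter). At this one concentration, compound 2 and compound 4 therefore cannot be told apart, whether a methyl or a hydrogen sits on this oxygen on an aromatic ring. No evidence bearing on this result is available. The compounds shown leave open whether an amine or a carboxylic acid at this place would read differently. They also leave open whether compound 2 and compound 4 would stay together at a higher concentration.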